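The source may report more compounds than this note shows. Statements on the series, on what has been measured and on what is new or still open speak of the compounds shown alone.

Going by the values given here, in a physicochemical assay for solubility, in phosphate buffer, at pH 7.4 (a lower number here means a less soluble compound, a higher number a more soluble compound), compound 3 `CCOC(=O)c1c(-c2ccccc2Cl)[nH]c2cc(OC)ccc2c1=O` gives 28000 nM, the only true number among the three measured compounds. Compound 1 `CCOC(=O)c1c(-c2cccc(F)c2)[nH]c2cc(OC)ccc2c1=O`, which carries 3-fluorophenyl, gives > 100000 nM, and this is a limit of the assay and not a number. Compound 2 `CCOC(=O)c1c(-c2ccccc2)[nH]c2cc(OC)ccc2c1=O` gives > 100000 nM, again a limit. The step that the two limits leave unreadable from compound 1 to compound 2 therefore says little.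

Compound 4 `CCOC(=O)c1c(-c2cccc([N+](=O)[O-])c2)[nH]c2cc(OC)ccc2c1=O` keeps the shared core but has 3-nitrophenyl in place of 2-chlorophenyl on an aromatic carbon, next to the ring nitrogen and ortho to an ethoxycarbonyl group (3-nitrophenyl in place of 2-chlorophenyl on an aromatic carbon).

Among the compounds with values here, two measured steps bear on this change: an at least 3.5-fold lower number from compound 1 to compound 3 (0.55 log units; beyond the scatter) and an at least 3.5-fold lower number from compound 2 to compound 3 (0.55 log units; beyond the scatter). On these data alone, both arrive at 2-chlorophenyl, both are at least modest, and each starts from a limit, so its full size remains open. Compound 4 gives up that 2-chlorophenyl, and its 3-nitrophenyl most resembles the 3-fluorophenyl of compound 1. However, no measured compound carries a nitro group, so only part of the drop is expected to reverse. The expected change is a modest rise, a 2.3-fold higher number from compound 3 to compound 4 (0.37 log units; beyond the scatter). For compound 4, the estimated value is 65000 nM, with an expected range from 25000 nM to 100000 nM.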

Compound 4, solubility: 13000 nM
Beside the measured number, compound 4's estimate is 5.0-fold (0.70 log units) above it; the whole stated range lies above it.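

In this assay, 3-nitrophenyl does not bring back the higher reading seen with 3-fluorophenyl: this change gives a 2.2-fold lower number from compound 3 to compound 4 (0.33 log units; beyond the scatter), so at this position, next to the ring nitrogen and ortho to an ethoxycarbonyl group, the number moves further down and compound 4 now has the lowest reading of the four. The comparisons with the two phenyl compounds point the same way, with nitro in place of hydrogen giving an at least 7.6-fold lower number from compound 2 to compound 4 (0.88 log units; beyond the scatter) and nitro in place of fluoro giving an at least 7.6-fold lower number from compound 1 to compound 4 (0.88 log units; beyond the scatter), which shows that 3-fluorophenyl and 3-nitrophenyl do not read alike here and that a chloro group on the phenyl ring is not needed for a lower number. Compound 1 and compound 2 each sit at a limit of the assay and not at a number, so the full size of these two steps stays open: the limit of > 100000 nM in this assay, at which 2 of the 4 values shown sit.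

Chloro appears here only in 2-chlorophenyl and nitro only in 3-nitrophenyl, so the effect of the group cannot be separated from that of its place on the phenyl ring, and 3-chlorophenyl or 2-nitrophenyl would be needed to do so. On these data alone, how an amine or a carboxylic acid on this phenyl ring would read in this assay also remains open.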